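Methyl Ester of a Pyrazole Acid: Expected Antiproliferative Potency

This account rests on a few compounds, and the source may have more. Where it says the series, first, only, none or still open, it means among the compounds named here.

The measured compounds:
compound 1, `COc1ncc(-c2ccc3ncnc(Nc4ccc(OCCO)c(F)c4)c3c2)cc1NS(=O)(=O)c1ccc(F)cc1F`, in a functional assay on A549 cells (Homo sapiens) for antiproliferative activity, read by sulforhodamine B assay, with a stated time of 72 h (a lower number here means a stronger inhibitor, a higher number a weaker inhibitor), gives 6640 nM
compound 2, `COc1ncc(-c2ccc3ncnc(Nc4cnn(CC(=O)O)c4)c3c2)cc1NS(=O)(=O)c1ccc(F)cc1F`, in this assay gives 5200 nM

Compound 2 has the lowest of the two numbers, but its nearest neighbour, compound 1, differs from it by only a 1.3-fold lower number from compound 1 to compound 2 (0.11 log units; within the scatter), a gap within the scatter, so the two are not distinguishable on these data.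

Compound 3, `COC(=O)Cn1cc(Nc2ncnc3ccc(-c4cnc(OC)c(NS(=O)(=O)c5ccc(F)cc5F)c4)cc23)cn1`, is the methyl ester of compound 2. The change is methyl in place of hydrogen on an oxygen next to a carbonyl group. Within the data shown here, the only measured step, from compound 1 to compound 2, concerns a different part of the molecule, the group on the nitrogen attached to the shared core, and it stayed within the scatter. Among the measured compounds shown here, no measured step therefore bears directly on turning the acid into its methyl ester. With nothing to indicate a large effect, the expectation for this assay is a modest step, a 1.5-fold lower number from compound 2 to compound 3 (0.17 log units; within the scatter), not clearly beyond the scatter. On that basis compound 3 is estimated to give 3500 nM, with a plausible range from 1000 nM to 12000 nM.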

Compound 3, half-maximal inhibitory concentration: 4280 nM
Compound 3: middle estimate off by 1.2-fold (0.09 log units), on the low side; the measured number falls inside the stated range.
By their numbers in this assay, from the lowest: compounds 3, 2 and 1 (each within the scatter of the next).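

In this assay, methyl in place of hydrogen on an oxygen next to a carbonyl group turns the carboxy group into methoxycarbonyl (a 1.2-fold lower number from compound 2 to compound 3 (0.08 log units; within the scatter)), so the acid and its methyl ester cannot be told apart at this position on these data. The larger swap on the nitrogen, 1-((methoxycarbonyl)methyl)-1H-pyrazol-4-yl in place of 3-fluoro-4-(2-hydroxyethoxy)phenyl (a 1.6-fold lower number from compound 1 to compound 3 (0.19 log units; within the scatter)), also stays within the scatter, which means that all three groups shown on that nitrogen now read alike in this assay. Nothing measured here beyond these antiproliferative numbers bears on the result.

Still open, as far as these compounds go, is whether a different replacement for the carboxymethyl group, such as a primary amide, an amine or a longer chain ending in a carboxylic acid, would give a step beyond the scatter. It is also unknown whether a bulkier ester, such as an ethyl or tert-butyl ester, would read the same as the methyl ester of compound 3 or move clearly away from it.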